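Fluoro in place of amino on the shared core

The source may hold more compounds than are shown below. What is called first, only, known or untested is meant among the compounds shown, and "the series" means these compounds.

Compound 1 `N#Cc1c(N)cccc1S(=O)(=O)c1cc(Cl)cc(Cl)c1`: > 200000 nM
Compound 2 `Cc1cc(Cl)cc(S(=O)(=O)c2cccc(N)c2C#N)c1`: > 200000 nM

In a functional assay on MT4 cells (Homo sapiens) for cytotoxicity (a higher number here means a weaker inhibitor, a lower number a stronger inhibitor), compound 1 gives > 200000 nM, which is a limit and not a number. Compound 2 gives > 200000 nM, which is also a limit. Compound 1 thus stands at the limit of > 200000 nM in this assay, at which 2 of the 2 values shown sit. Among the compounds with values here, the only measured step is a step that the two limits leave unreadable from compound 1 to compound 2, and it concerns methyl in place of chloro, not the change considered here.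

Compound 3 `N#Cc1c(F)cccc1S(=O)(=O)c1cc(Cl)cc(Cl)c1` differs from compound 1 by fluoro in place of amino on an aromatic carbon. Within the data shown here, no measured step covers this exchange, so the data give no size for it. Compound 3 is expected to stay close to the limit in this assay, and any readable number would be expected to fall on the lower side. The estimated step is an at least 1.3-fold lower number from compound 1 to compound 3 (0.12 log units; that floor lies within the scatter). For compound 3 the expected value is 150000 nM, with an estimated range of 40000 nM to 300000 nM.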

Compound 3, half-maximal inhibitory concentration: 188000 nM
Compound 3: the middle estimate sits 1.3-fold (0.10 log units) below what was measured; measured number inside the range.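

In this assay, fluoro in place of amino on an aromatic carbon ortho to a cyano group gives the only readable number among the compounds shown, with compound 3 at 188000 nM. The exchange reads as an at least 1.0-fold lower number from compound 1 to compound 3 (0.02 log units; that floor lies within the scatter), so the data fix only a floor for this step and no upper size. The other values remain limits of the assay and not numbers: the limit of > 200000 nM in this assay, at which 2 of the 3 values shown sit.

From the compounds shown here alone, the step from compound 1 to compound 2 cannot be read, and the true size of the exchange from amino to fluoro stays open. Also open, going by these compounds, is whether a hydroxyl, a methoxy or a carboxylic acid at this position would give a number clearly lower than that of compound 3 in this assay.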